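Replacing the 1-benzofuran-5-yl group of compound 3

This account rests on a few compounds, and the source may have more. Where it says the series, first, only, none or still open, it means among the compounds named here.

Measured in a functional assay on K562 cells (Homo sapiens) for inhibition, read by trypan blue exclusion, with a stated time of 72 h; on this read-out lower numbers stand for stronger inhibition and higher numbers for weaker inhibition:
- compound 1 `Cn1c(=O)c(S(=O)(=O)c2ccc(F)cc2)cc2cnc(Nc3ccc4occc4c3)nc21` gives 5000 nM
- compound 2 `CCCn1c(=O)c(S(=O)(=O)c2ccc(F)cc2F)cc2cnc(Nc3ccc4[nH]ccc4c3)nc21` gives 1000 nM
- compound 3 `Cn1c(=O)c(S(=O)(=O)c2ccc(F)cc2F)cc2cnc(Nc3ccc4occc4c3)nc21` gives 15000 nM

Compound 3 has the highest number of the three, so it is the weakest inhibitor here. Compound 4 `Cn1c(=O)c(S(=O)(=O)c2ccc(F)cc2F)cc2cnc(Nc3ccc4c(c3)CC(=O)N4)nc21` differs from it thus: a group of 10 heavy atoms (8 carbon, 1 nitrogen, 1 oxygen; one five-membered non-aromatic ring with 1 hetero atom, one six-membered aromatic ring of carbon only) in place of a group of 9 heavy atoms (8 carbon, 1 oxygen; one five-membered aromatic ring with 1 hetero atom, one six-membered aromatic ring of carbon only), on a nitrogen on an aromatic ring. Within the data shown here, the only measured single-place step, a 3.0-fold higher number from compound 1 to compound 3 (0.48 log units; beyond the scatter), concerns a fluoro in place of hydrogen and says little about this exchange. Compound 2 reads lower at 1000 nM but differs from compound 3 in more than one place, so it is weak guidance. A modest fall is expected in this assay, an estimated 2.5-fold lower number from compound 3 to compound 4 (0.40 log units; beyond the scatter). The value estimated for compound 4 is 6000 nM, with an expected range from 1500 nM to 20000 nM.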

Compound 4, half-maximal inhibitory concentration: 15000 nM
The estimate for compound 4 lay 2.5-fold (0.40 log units) below the measured number; low and high end bracket the measured number.
By their numbers in this assay, from the lowest: compound 2; then compound 1; then compounds 3 and 4 (each within the scatter of the next).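

In this assay, putting the new group in place of 1-benzofuran-5-yl on this nitrogen gives no change at the digits printed from compound 3 to compound 4 (within the scatter). The five-membered ring can thus turn non-aromatic and the entering group can bring a hydrogen-bond donor without any readable shift in the number, at least on this weak background. No measurement here offers an explanation for this flat result. From the compounds shown here alone, whether an amine or a carboxylic acid on the group at this nitrogen would move the number remains open. So does whether this exchange would read the same on the core of compound 1.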